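Swapping a trifluoromethyl benzyl ether for a chlorobenzyl ether

A few compounds are considered here, and "the series" means these few. Any claim that something is new, unique, unknown or untested is made for them only; others in the source may bear on it.

Compound 1 `COc1ccc2c(=O)c(-c3cc(OC)c(OC)cc3OC)coc2c1` gives 5200 nM in a functional assay on B16 cells (Mus musculus) for antiproliferative activity, read by MTT assay, with a stated time of 24 h; a lower number here means a stronger inhibitor, a higher number a weaker inhibitor. Compound 2 `COc1cc(OC)c(-c2coc3cc(OCc4ccc(F)cc4)ccc3c2=O)cc1OC` gives 1120 nM, and compound 3 `COc1cc(OC)c(-c2coc3cc(OCc4ccccc4C(F)(F)F)ccc3c2=O)cc1OC` gives 8550 nM, the highest of the three numbers; its gap to compound 1 lies within the scatter, while the step of a 7.6-fold higher number from compound 2 to compound 3 (0.88 log units; beyond the scatter) lies beyond it. Compound 4 `COc1cc(OC)c(-c2coc3cc(OCc4ccc(Cl)cc4)ccc3c2=O)cc1OC` differs from compound 3 by 4-chlorophenyl in place of 2-(trifluoromethyl)phenyl on a saturated chain carbon bound to an oxygen on an aromatic ring. The steps of a 4.6-fold lower number from compound 1 to compound 2 (0.67 log units; beyond the scatter) and a 1.6-fold higher number from compound 1 to compound 3 (0.22 log units; within the scatter) show that a 4-fluorophenyl at this place lowered the number while a 2-(trifluoromethyl)phenyl did not. Because compound 2 gives 1120 nM with a 4-fluorophenyl at this place, and 4-chlorophenyl resembles it, compound 4 is expected to land nearby, a step of a 7.1-fold lower number from compound 3 to compound 4 (0.85 log units; beyond the scatter). The estimate for compound 4 is 1200 nM, ranging from 400 nM to 4000 nM.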

Compound 4, half-maximal inhibitory concentration: 2400 nM
Compound 4: the middle estimate sits 2.0-fold (0.30 log units) below what was measured, within the range that was stated.
By their numbers in this assay, from the lowest: compound 2; then compound 4; then compounds 1 and 3 (each within the scatter of the next).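

Compound 4 shows that the gain at this place is not limited to 4-fluorophenyl: 4-chlorophenyl also improves on the hydrogen, with a 2.2-fold lower number from compound 1 to compound 4 (0.34 log units; beyond the scatter) as the step. Chloro in place of fluoro on an aromatic carbon is not a neutral swap, giving a 2.1-fold higher number from compound 2 to compound 4 (0.33 log units; beyond the scatter) and favouring the fluoro group. The 4-chlorophenyl still clearly beats 2-(trifluoromethyl)phenyl, with a 3.6-fold lower number from compound 3 to compound 4 (0.55 log units; beyond the scatter) between them. As far as these compounds go, how an unsubstituted phenyl or a pyridine ring would behave at this place stays open. Nothing available here explains these differences.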